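Swapping the pendant ring on the saturated carbon

The compounds below may be only part of what the source reports. "The series", "measured", "known", "first", "only" and "open" are said of these compounds alone.

Measured so far:
compound 1 `O=C1CC(c2cnco2)CN1c1cnn2c1CN(C(=O)Nc1cc(F)c(F)c(F)c1)C(C1CC1)C2`: 139000 nM
compound 2 `O=C1CC(Oc2ncc(F)cn2)CN1c1cnn2c1CN(C(=O)Nc1cc(F)c(F)c(F)c1)C(C1CC1)C2`: 96200 nM

In a toxicity assay on HepG2 2.2.15 cells (Homo sapiens) for cytotoxicity, read by CellTiter-Glo (on this read-out higher numbers stand for lower toxicity in this test and lower numbers for higher toxicity in this test), compound 2 gives the lower of the two numbers, but it sits within the scatter of compound 1, as the step of a 1.4-fold lower number from compound 1 to compound 2 (0.16 log units; within the scatter) shows. Compound 3 `O=C1CC(c2ccc(F)cn2)CN1c1cnn2c1CN(C(=O)Nc1cc(F)c(F)c(F)c1)C(C1CC1)C2` differs from compound 2 by 5-fluoropyridin-2-yl in place of (5-fluoropyrimidin-2-yl)oxy on a saturated ring carbon. Among the compounds with values here, the only comparable step, a 1.4-fold lower number from compound 1 to compound 2 (0.16 log units; within the scatter), also swapped the group on this saturated ring carbon and stayed within the scatter. A change within the scatter is therefore expected for compound 3 as well, a 1.2-fold higher number from compound 2 to compound 3 (0.10 log units; within the scatter). Compound 3 is estimated at 120000 nM, ranging from 60000 nM to 240000 nM.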

Compound 3, half-maximal cytotoxic concentration: 38500 nM
For compound 3 the middle estimate is 3.1-fold (0.49 log units) above the measured one, outside the stated range (below it).
By their numbers in this assay, from the lowest: compound 3; then compounds 2 and 1 (each within the scatter of the next).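

The group on this saturated ring carbon can shift the read-out beyond the scatter after all: this assay shows a 2.5-fold lower number from compound 2 to compound 3 (0.40 log units; beyond the scatter) and a 3.6-fold lower number from compound 1 to compound 3 (0.56 log units; beyond the scatter) as modest steps. Compound 3, with 5-fluoropyridin-2-yl, is therefore the most toxic of the three in this test. Nothing given here explains the shift.

The step from compound 2 removes the linking oxygen and one ring nitrogen together, so the compounds shown cannot separate these two changes. On these data alone, how an amine or a carboxylic acid on this carbon would read also remains open.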